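The source may report more compounds than this note shows. Statements on the series, on what has been measured and on what is new or still open speak of the compounds shown alone.

Compound 2 `CC(C)c1ccc(N/N=C2\CCC(C)n3c2ncc(C(=O)O)c3=O)cc1` was tested in a functional assay on the whole organism for inhibition, with Rattus norvegicus as the target; on this read-out higher numbers stand for an effect only at larger amounts of compound and lower numbers for an effect already at smaller amounts. In this assay compound 2 gives > 100 umol/kg, which is only a limit of the assay, not a measured number. Compound 1 `CC1CC/C(=N\Nc2ccc(Br)cc2)c2ncc(C(=O)O)c(=O)n21` carries bromo where compound 2 carries isopropyl on an aromatic carbon. In this assay compound 1 gives > 1000 umol/kg, again only a limit. The step that the two limits leave unreadable from compound 1 to compound 2 is thus unreadable. Compound 3 `CC1CC/C(=N\Nc2ccc(-c3ccccc3)cc2)c2ncc(C(=O)O)c(=O)n21` carries the change (phenyl in place of isopropyl on an aromatic carbon). Among the measured compounds shown here, no measured step speaks to this change, so no shift beyond the scatter is expected. Compound 3 is estimated at 300 umol/kg, in the range 50 umol/kg to 3000 umol/kg. The expected step is a step that the limit leaves unreadable from compound 2 to compound 3.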

Compound 3, dose for 50% inhibition: > 100 umol/kg
Compound 3: no number, only a limit; the forecaster's own chance of this, stated with the estimate: 80%; the middle value is on the limit's open side.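

In this assay, among the compounds shown here, compound 1, compound 2 and compound 3 each give only a limit, so no step between them can be read. As far as these compounds go, whether bromo, isopropyl or phenyl changes the dose needed remains open.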